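This account rests on a few compounds, and the source may have more. Where it says the series, first, only, none or still open, it means among the compounds named here.

Of the compounds shown here, two have so far been measured in an ADME assay on microsomes from liver (Mus musculus) for metabolic stability, read by LC-MS, using NADPH, with a stated time of 30 min, tested at 0.1 uM; a lower number here means that less of the compound is left, a higher number that more of the compound is left. Within the data shown here, compound 1 `O=S(=O)(NCCO)c1cccc(Nc2ccc3nccc(-c4ccncc4)c3n2)c1` is the one of the pair with more left at the end: in this assay compound 1 gives 38%. Compound 2 `NS(=O)(=O)c1cncc(-c2ccc3nccc(-c4cn[nH]c4)c3n2)c1` differs from it in several places at once, and in this assay compound 2 gives 2%, a gap well beyond the usual scatter, so compound 1 stands highest of the two numbers. The two differ in more than one place, so no single change can be read from that gap.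

Compound 3 `O=S(=O)(NCc1ccccc1)c1cccc(Nc2ccc3nccc(-c4ccncc4)c3n2)c1` has not yet been measured. It differs from compound 1 in one place only: phenyl in place of hydroxymethyl on a saturated chain carbon bound to a sulfonamide nitrogen. Among the measured compounds shown here, no pair of measured compounds shows what this change does, so any expectation rests on the starting value of compound 1 alone. For compound 3 the expected step is a number 18 percentage points lower from compound 1 to compound 3 (beyond the scatter), a drop beyond the scatter but not a dramatic one. The estimate for compound 3 is 20%, with a plausible range from 5% to 40%.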

Compound 3, percent of the compound remaining: 2%
Beside the measured number, compound 3's estimate is 18 percentage points above it; the measured number lies below the stated range.
By their numbers in this assay, from the lowest: compounds 2 and 3 (each within the scatter of the next); then compound 1.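

In this assay, among these compounds, this is the first change in a single place that can be read, and it is large: replacing hydroxymethyl with phenyl on a saturated chain carbon bound to a sulfonamide nitrogen gives a number 36 percentage points lower from compound 1 to compound 3 (beyond the scatter). The earlier pair differed in several places at once, whereas here the rest of the molecule stays the same, so the fall belongs to this one change and shows that the group at this position strongly affects how much compound is left. No measurement at hand explains the fall.

The change removes a hydroxyl-bearing group and adds an aromatic ring in the same step, so the compounds leave open whether the loss of the one or the gain of the other accounts for the step, a question that a plain ethyl on the sulfonamide nitrogen could help to separate. Also open, as far as these compounds go, is how a carboxylic acid or an amine at the end of the chain, or a longer chain ending in a hydroxyl, would behave in this assay.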